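Methoxy step on two related cores

This account rests on a few compounds, and the source may have more. Where it says the series, first, only, none or still open, it means among the compounds named here.

Series notes in an assay on isolated protein for inhibition of Amine oxidase [flavin-containing] A (Homo sapiens), read by fluorescence; a lower number here means a stronger inhibitor, a higher number a weaker inhibitor:
- compound 1 `N#Cc1cc2[nH]c(-c3ccccc3)c(Cl)c2cc1C#N` gives 121 nM
- compound 2 `COc1ccc(-c2[nH]c3cc(C#N)c(C#N)cc3c2Cl)cc1` gives 4 nM
- compound 3 `N#Cc1cc2c(Br)c(-c3ccccc3)n(O)c2cc1C#N` gives 3480 nM

Compound 2 arises from compound 1 by methoxy in place of hydrogen on an aromatic carbon, the step being a 30-fold lower number from compound 1 to compound 2 (1.48 log units; beyond the scatter). Compound 3 differs from compound 1 in more than one place; the difference between the two cores is not broken down here. Compound 3 gives the highest number of the three. Compound 4 `COc1ccc(-c2c(Br)c3cc(C#N)c(C#N)cc3n2O)cc1` is not yet measured in this assay; it arises from compound 3 by methoxy in place of hydrogen on an aromatic carbon, the same change as that from compound 1 to compound 2. That change is measured on one pair only, and only on the core of compound 1. For compound 4 a step of a 12-fold lower number from compound 3 to compound 4 (1.06 log units; beyond the scatter) is expected, somewhat smaller than the measured one, because the step of a 30-fold lower number from compound 1 to compound 2 (1.48 log units; beyond the scatter) rests on a single pair on a different core. Compound 4 is expected at 300 nM, between 80 nM and 1200 nM.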

Compound 4, half-maximal inhibitory concentration: 726 nM
The estimate for compound 4 lay 2.4-fold (0.38 log units) below the measured number; the range from low to high includes it.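

Methoxy in place of hydrogen on an aromatic carbon, para to a large group, also lowers the number on the second core: in this assay the new step is a 4.8-fold lower number from compound 3 to compound 4 (0.68 log units; beyond the scatter). The direction carries from one core to the other, but the size does not: the same change on two cores in this assay, a 30-fold lower number (1.48 log units; beyond the scatter) from compound 1 to compound 2 and a 4.8-fold lower number (0.68 log units; beyond the scatter) from compound 3 to compound 4, 6.3-fold (0.80 log units) apart, beyond the scatter of two such steps. With a single pair on each core, this does not show which of the differences between the cores goes with the smaller step, nor what a third core would give.

As far as these compounds go, whether an ethoxy group or an amine in the place of the methoxy would give steps of like size stays open. Also open, from the compounds shown here alone, is how the methoxy step runs on a core that differs from the core of compound 1 in one place only.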